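The source may hold more compounds than are shown below. What is called first, only, known or untested is meant among the compounds shown, and "the series" means these compounds.

Compound 1 `Cc1ccc2c(=O)c(CSC(=S)N(C(C)C)C(C)C)coc2c1` gives 240 nM in a functional assay on MDA-MB-435S cells (Homo sapiens) for antiproliferative activity, read by MTT assay, with a stated time of 72 h; a lower number here means a stronger inhibitor, a higher number a weaker inhibitor. Compound 2 `O=c1c(Cl)c(CSC(=S)N2CCCC2)oc2ccccc12` gives 1800 nM in this assay. Compound 3 `CC(C)N(C(=S)SCc1coc2cc(Cl)ccc2c1=O)C(C)C` reaches only a limit of this assay, > 25000 nM (the limit of > 25000 nM in this assay, at which 1 of the 3 values shown sits).

Of the two numbers shown, compound 1 holds the lowest; compound 2 sits at a higher number. Compound 4 `Cc1ccc2c(=O)c(CSC(=S)N3CCOCC3)coc2c1` differs from compound 1 in one place (morpholin-4-yl in place of diisopropylamino on a thiocarbonyl carbon). Among the compounds with values here, the single measured step, an at least 100-fold higher number from compound 1 to compound 3 (2.01 log units; beyond the scatter), concerns chloro in place of methyl on an aromatic carbon and says nothing about the thiocarbonyl carbon. Compound 2 differs from compound 1 in more than one place, so its value cannot be assigned to the amine alone. No step beyond the scatter is therefore firmly expected, though the direction is open. Compound 4 is estimated at 600 nM, between 150 nM and 3000 nM, which means an expected 2.5-fold higher number from compound 1 to compound 4 (0.40 log units; beyond the scatter).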

Compound 4, half-maximal inhibitory concentration: 5500 nM
Compound 4: middle estimate off by 9.2-fold (0.96 log units), on the low side; the whole stated range lies below it.
By their numbers in this assay, from the lowest: compound 1; then compound 2; then compound 4. At a limit, above all of these: compound 3.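

The amine on the thiocarbonyl carbon proves to be a sensitive place in this assay, with morpholin-4-yl in place of diisopropylamino giving a large loss (a 23-fold higher number from compound 1 to compound 4 (1.36 log units; beyond the scatter)). Within the data shown here, earlier, the only step that could be read concerned chloro in place of methyl on an aromatic carbon, so this is the first evidence that the thiocarbonyl side alone can move the value beyond the scatter. No measurement shown gives a cause for this step.

On these data alone, whether piperidin-1-yl or diethylamino on this carbon would stay close to compound 1 or fall towards compound 4 remains open.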